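A few compounds are considered here, and "the series" means these few. Any claim that something is new, unique, unknown or untested is made for them only; others in the source may bear on it.

Compound 1 `C#CCn1cc(C(=O)NC(CC(=O)NC2CCCCC2)c2ccccc2)c(=O)c2cc(F)c(Cl)nc21` was tested in a functional assay on A549 cells (Homo sapiens) for cytotoxicity, read by MTT assay, with a stated time of 72 h; a higher number here means a weaker inhibitor, a lower number a stronger inhibitor. Compound 1 gives only a limit there, > 10000 nM. Compound 2 `C#CCn1cc(C(=O)NC(CC(=O)Nc2ccccc2)c2ccccc2)c(=O)c2ccc(Cl)nc21` also gives only a limit, > 10000 nM. Compound 3 `C#CCn1cc(C(=O)NC(CC(=O)Nc2ccccc2)c2ccccc2)c(=O)c2cccnc21` likewise gives only a limit, > 10000 nM. The single step measured among these, a step that the two limits leave unreadable from compound 2 to compound 3, stays unreadable because of the limit of > 10000 nM in this assay, at which 3 of the 3 values shown sit. Compound 4 `C#CCn1cc(C(=O)NC(CC(=O)NC2CCCC2)c2ccccc2)c(=O)c2cc(F)c(Cl)nc21` has not yet been measured; the change from compound 1 is cyclopentyl in place of cyclohexyl on an amide-type nitrogen. Within the data shown here, no measured step touches this part of the structure, so the expectation rests only on compounds 1, 2 and 3 all sitting at the limit. Compound 4 is therefore expected to remain at or near that limit, with an estimated step that the limit leaves unreadable from compound 1 to compound 4. The estimate for compound 4 in this assay is 20000 nM, ranging from 8000 nM to 60000 nM.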

Compound 4, half-maximal inhibitory concentration: 6100 nM
Compound 4: the middle estimate sits 3.3-fold (0.52 log units) above what was measured; measured number outside the range, below it.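

In this assay, among these compounds, cyclopentyl in place of cyclohexyl on the amide-type nitrogen yields the first readable number in this set, with an at least 1.6-fold lower number from compound 1 to compound 4 (0.21 log units; that floor lies within the scatter). This position can therefore take a change that brings the value inside the measured range, although the floor of the step does not clear the usual scatter. As far as these compounds go, the true size of the step stays unknown because one end of it is a limit: the limit of > 10000 nM in this assay, at which 3 of the 4 values shown sit. The compounds shown leave open how a cyclobutyl ring, an open isopropyl chain or a cyclohexyl ring carrying an amine would read here.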